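The source may hold more compounds than are shown below. What is called first, only, known or untested is meant among the compounds shown, and "the series" means these compounds.

Compounds in an ADME assay on the whole organism (strain Han-Wistar) for metabolic stability, with Rattus norvegicus as the target, read by LC-MS, at a dose of 1 mg/kg by the intravenous route; a lower number here means that the compound disappears faster, a higher number that the compound lasts longer:
- compound 1 `Cc1ccc([C@@H](C)Oc2cc3onc(CCC(=O)O)c3cc2Cl)nn1`: 1.5 h
- compound 2 `C[C@@H](Oc1cc2onc(CCC(=O)O)c2cc1Cl)c1ccc(Cl)cn1`: 8.7 h
- compound 3 `C[C@@H](Oc1cc2onc(CCC(=O)O)c2cc1Cl)c1ccccn1`: not yet measured

Compound 2 stands highest of the two measured compounds. The next change is hydrogen in place of chloro on an aromatic carbon, para to a large group. Among the measured compounds shown here, only one measured step bears on it, and only indirectly: a 5.8-fold higher number from compound 1 to compound 2 (0.76 log units; beyond the scatter), where the whole aromatic group was exchanged. For the measured compounds named here, no measured pair isolates the chloro alone. A drop smaller than that step is therefore expected in this assay, though it may not clear the scatter. The expected change is a 1.9-fold lower number from compound 2 to compound 3 (0.29 log units; within the scatter). For compound 3 the estimated half-life is 4.5 h, with an expected range of 1.8 h to 9.5 h.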

Compound 3, half-life: 6.6 h
Compound 3: the middle estimate sits 1.5-fold (0.17 log units) below what was measured, and the stated range covers the measured number.
By their numbers in this assay, from the lowest: compound 1; then compounds 3 and 2 (each within the scatter of the next).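

In this assay hydrogen in place of chloro gives a 1.3-fold lower number from compound 2 to compound 3 (0.12 log units; within the scatter) and so, at this place para to a large group, the chloro alone makes no step beyond the scatter. The pyridin-2-yl without chloro still gives a 4.4-fold higher number from compound 1 to compound 3 (0.64 log units; beyond the scatter) and so the step away from 6-methylpyridazin-3-yl does not depend on the chloro. No evidence at hand explains either step.

Open, on these data alone, is whether fluoro, methoxy or nitrile at this place would separate from chloro and hydrogen. Also open, as far as these compounds go, is whether a methyl there would read the same.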